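This account rests on a few compounds, and the source may have more. Where it says the series, first, only, none or still open, it means among the compounds named here.

Three compounds sharing one core were tested in an assay on CHO cells for displacement of a labelled ligand from adenosine receptor A1 (Homo sapiens), read by scintillation counting, with a stated time of 60 min, tested at 10 uM; on this read-out lower numbers stand for less inhibition and higher numbers for more inhibition at the one concentration tested (going by the name of the read-out). Compound 1 `CNC(=O)[C@@]12C[C@@H]1[C@@H](n1cnc3c(NC)nc(C#Cc4cccc(F)c4)nc31)[C@H](O)[C@@H]2O` gives 14%, compound 2 `CNC(=O)[C@@]12C[C@@H]1[C@@H](n1cnc3c(NC)nc(C#Cc4ncccn4)nc31)[C@H](O)[C@@H]2O` gives 25%, and compound 3 `CNC(=O)[C@@]12C[C@@H]1[C@@H](n1cnc3c(NC)nc(C#Cc4cnn(C)c4)nc31)[C@H](O)[C@@H]2O` gives 35%. Compound 3 lies clearly above compound 1, the step of a number 21 percentage points higher from compound 1 to compound 3 (beyond the scatter) being beyond the scatter, whereas against compound 2 the step of a number 10 percentage points higher from compound 2 to compound 3 (within the scatter) is within the scatter, so those two cannot be told apart. Compound 4 `CNC(=O)[C@@]12C[C@@H]1[C@@H](n1cnc3c(NC)nc(C#CC4CC4)nc31)[C@H](O)[C@@H]2O` differs from compound 3 in one place: cyclopropyl in place of 1-methyl-1H-pyrazol-4-yl on a triple-bonded carbon. All three measured steps swap the group on the triple-bonded carbon, with a number 11 percentage points higher from compound 1 to compound 2 (beyond the scatter) and a number 21 percentage points higher from compound 1 to compound 3 (beyond the scatter) beyond the scatter and a number 10 percentage points higher from compound 2 to compound 3 (within the scatter) within it, but none of them places a cyclopropyl there. Compound 1, carrying 3-fluorophenyl, gives the lowest number, and the higher numbers come with pyrimidin-2-yl and 1-methyl-1H-pyrazol-4-yl; the entering group resembles neither, so the direction is uncertain. Compound 4 is expected to drop modestly, an estimated step of a number 15 percentage points lower from compound 3 to compound 4 (beyond the scatter) in this assay. Compound 4 is therefore estimated at 20%, within a range from 5% to 40%.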

Compound 4, a percentage reported as inhibition, at one concentration (the size of the read-out at that concentration, not a potency): 38%
Compound 4: middle estimate off by 18 percentage points, on the low side, within the range that was stated.
By their numbers in this assay, from the lowest: compound 1; then compounds 2, 3 and 4 (each within the scatter of the next, the first and the last beyond it).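

In this assay the step of a number 3 percentage points higher from compound 3 to compound 4 (within the scatter) means that cyclopropyl and 1-methyl-1H-pyrazol-4-yl cannot be told apart on the triple-bonded carbon, even though the entering group is a three-membered carbon ring with 0 hydrogen-bond acceptors and the leaving one is an aromatic ring with 2. Cyclopropyl also stands clear of the other two groups, with a number 13 percentage points higher from compound 2 to compound 4 (beyond the scatter) and a number 24 percentage points higher from compound 1 to compound 4 (beyond the scatter), so among these compounds neither an aromatic ring nor a hydrogen-bond acceptor in this group is needed to reach this level of inhibition. Nothing available explains why these groups give these numbers.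

From the compounds shown here alone, it remains open whether an open carbon chain such as propyl, or a short chain ending in an amine or a hydroxyl group, would read like cyclopropyl here. Each compound also has a reading at only one concentration, which leaves its potency open.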